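A few compounds are considered here, and "the series" means these few. Any claim that something is new, unique, unknown or untested is made for them only; others in the source may bear on it.

In a functional assay on HeLa cells (Homo sapiens) for inhibition (a lower number here means a stronger inhibitor, a higher number a weaker inhibitor), compound 1 `O=C(CC(CC(=O)NC1Cc2ccccc2C1)c1ccccc1)NCCN1CCCC1` reads > 100000 nM, which is a limit of the assay and not a number. Compound 3 `CN(C(=O)CC(CC(=O)NCCN1CCCC1)c1ccccc1)C1Cc2ccccc2C1` reads > 100000 nM, also a limit and not a number. Going by the values given here, compound 2 `CCN(C(=O)CC(CC(=O)NCCN1CCCC1)c1ccc(Cl)cc1)C1Cc2ccccc2C1` gives 36400 nM, the only true number in this small set. Compound 3 therefore stands with compound 1 at the limit of > 100000 nM in this assay, at which 2 of the 3 values shown sit, and its real value is not known.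

Compound 4 `CCN(C(=O)CC(CC(=O)NCCN1CCCC1)c1ccccc1)C1Cc2ccccc2C1` differs from compound 3 by one small change: methyl in place of hydrogen on a saturated chain carbon bound to an amide-type nitrogen. This is methyl in place of hydrogen on a saturated chain carbon bound to an amide-type nitrogen, so a methyl becomes an ethyl. Among the compounds with values here, the one measured step that bears on it is a step that the two limits leave unreadable from compound 1 to compound 3, which changes the same amide-type nitrogen. It gives no size to build on, so only a modest shift can be expected. The value of compound 2, 36400 nM, shows that a true number can be read in this assay, so a slight move toward a lower number is expected. A real chance of another limit remains. The estimated change is an at least 1.2-fold lower number from compound 3 to compound 4 (0.09 log units; that floor lies within the scatter). For compound 4 the expected value is 80000 nM, with an estimated range from 30000 nM to 150000 nM.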

Compound 4, half-maximal inhibitory concentration: > 100000 nM
Compound 4: no number, only a limit; the forecaster's own chance of this, stated with the estimate: 55%; at least 1.2-fold (0.09 log units) between middle value and limit.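

In this assay, compound 4 gives a limit and not a number, and it joins the largest group in this small set: the limit of > 100000 nM in this assay, at which 3 of the 4 values shown sit.

The steps among compound 1, compound 3 and compound 4 cannot be read, so hydrogen, methyl and ethyl on the amide-type nitrogen cannot be ranked against one another. Going by these compounds alone, what the new compound does add is a matched partner for compound 2: with the ethyl kept in both, hydrogen in place of chloro on an aromatic carbon gives an at least 2.7-fold higher number from compound 2 to compound 4 (0.43 log units; beyond the scatter), which ties the only true number in the set to the chloro and shows that the ethyl alone does not bring a readable value.

Going by these compounds, it remains open whether the chloro would also give a readable number with methyl or hydrogen on the amide-type nitrogen, or whether it works only together with the ethyl. On these data alone, it is also open whether a fluoro or a methoxy on that aromatic carbon, or a longer chain such as propyl on the nitrogen, would give a lower number than compound 2 at 36400 nM.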